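Working notes: aryl exchange from compound 2 to compound 4

This account rests on a few compounds, and the source may have more. Where it says the series, first, only, none or still open, it means among the compounds named here.

Among the measured compounds shown here, in a functional assay on MCF7 cells (Homo sapiens) for inhibition, read by CCK-8 assay, with a stated time of 48 h (a lower number here means a stronger inhibitor, a higher number a weaker inhibitor), compound 2 `COc1cc(-c2ccnc3cc(-c4ccc(C(F)(F)F)cc4)nn23)cc(OC)c1OC` gives 2440 nM, the only real number in this small set. Compound 1 `COc1cc(-c2cc3nccc(-c4c[nH]c5ccccc45)n3n2)cc(OC)c1OC` sits at the limit > 10000 nM. Compound 3 `CCOC(=O)c1ccc(-c2cc3nccc(-c4cc(OC)c(OC)c(OC)c4)n3n2)cc1` likewise reaches only the limit > 10000 nM. For the measured compounds named here, the single measured step, an at least 4.0-fold higher number from compound 2 to compound 3 (0.61 log units; beyond the scatter), is therefore itself bounded by the limit of > 10000 nM in this assay, at which 2 of the 3 values shown sit. Compound 4 `COc1ccc(-c2cc3nccc(-c4cc(OC)c(OC)c(OC)c4)n3n2)cc1F` differs from compound 2 by 3-fluoro-4-methoxyphenyl in place of 4-(trifluoromethyl)phenyl on an aromatic carbon. It thus alters the same phenyl substituent that the step to compound 3 changed, and that step weakened the compound, while compound 1 also sits at the limit. Given an at least 4.0-fold higher number from compound 2 to compound 3 (0.61 log units; beyond the scatter) and the limit of compound 1, compound 4 is expected to give 7000 nM, within 2000 nM to 15000 nM, amounting to a 2.9-fold higher number from compound 2 to compound 4 (0.46 log units; beyond the scatter).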

Compound 4, half-maximal inhibitory concentration: 183 nM
The estimate for compound 4 lay 38-fold (1.58 log units) above the measured number; measured number outside the range, below it.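

In this assay, the exchange gives a 13-fold lower number from compound 2 to compound 4 (1.12 log units; beyond the scatter), so the aryl group at this position can move the number down as well as up, the latter seen in an at least 4.0-fold higher number from compound 2 to compound 3 (0.61 log units; beyond the scatter). This is the first step here with a real number at both ends, whereas the earlier step ends at a limit: the limit of > 10000 nM in this assay, at which 2 of the 4 values shown sit.

The compounds shown do not separate the contributions of the fluorine and the methoxy within 3-fluoro-4-methoxyphenyl. On these data alone, how an amine or a carboxylic acid on this phenyl ring would read remains open.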